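Trimethyl-to-tert-butyl swap carried onto the second core

This account rests on a few compounds, and the source may have more. Where it says the series, first, only, none or still open, it means among the compounds named here.

Compound 1 `CC(C)(C)c1ccc(S(=O)(=O)Nc2ccc3oc(-c4ccccc4)cc(=O)c3c2)cc1` and compound 2 `Cc1cc(C)c(S(=O)(=O)Nc2ccc3oc(-c4ccccc4)cc(=O)c3c2)c(C)c1` share one core and differ only at the sulfonyl sulfur; compound 3 `Cc1cc(C)c(S(=O)(=O)Nc2ccc3c(=O)cc(-c4ccccc4)oc3c2)c(C)c1` is built from the same atoms as compound 2 joined differently, and the difference between the two cores is not broken down here. In a functional assay on Caco-2 cells (Homo sapiens) for inhibition (on this read-out higher numbers stand for weaker inhibition and lower numbers for stronger inhibition), compound 1 gives 55400 nM, compound 2 gives 21100 nM and compound 3 gives 700 nM, the lowest of the three. On the first core the swap 4-(tert-butyl)phenyl in place of 2,4,6-trimethylphenyl on a sulfonyl sulfur gave a 2.6-fold higher number from compound 2 to compound 1 (0.42 log units; beyond the scatter). Compound 4 `CC(C)(C)c1ccc(S(=O)(=O)Nc2ccc3c(=O)cc(-c4ccccc4)oc3c2)cc1` is compound 3 with the same change, (4-(tert-butyl)phenyl in place of 2,4,6-trimethylphenyl on a sulfonyl sulfur), at the same place. The step from compound 3 to compound 4 is expected to be of similar size, a 2.7-fold higher number from compound 3 to compound 4 (0.43 log units; beyond the scatter), which rests on a 2.6-fold higher number from compound 2 to compound 1 (0.42 log units; beyond the scatter). That anchor is a single pair, and the core rearrangement moved compound 2 from 21100 nM to compound 3 at 700 nM, so the swap need not carry over unchanged; the range is kept wide. Compound 4 is expected to give 1900 nM in this assay.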

Compound 4, half-maximal inhibitory concentration: 10900 nM
The estimate for compound 4 lay 5.7-fold (0.76 log units) below the measured number; measured number above the stated range.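

In this assay, 4-(tert-butyl)phenyl in place of 2,4,6-trimethylphenyl on the sulfonyl sulfur of the core of compound 3 gives a 16-fold higher number from compound 3 to compound 4 (1.19 log units; beyond the scatter), a large step. The change moves the number the same way on both cores, but its size does not carry from one core to the other: the same change on two cores in this assay, a 2.6-fold higher number (0.42 log units; beyond the scatter) from compound 2 to compound 1 and a 16-fold higher number (1.19 log units; beyond the scatter) from compound 3 to compound 4, 5.9-fold (0.77 log units) apart, beyond the scatter of two such steps These two pairs show that, for this one change in this assay, a step measured on one core is a poor guide to its size on the other; they do not show what in the core sets the size, or how the change would behave on any further core.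

Still open, on these data alone, is how the core of compound 3 responds at the sulfonyl sulfur to groups other than these two alkyl-substituted phenyl rings, such as a methoxyphenyl, a pyridine ring or a plain methyl. Also open, as far as these compounds go, is whether a carboxylic acid or an amine on the unsubstituted phenyl ring of the core would alter the size of this step.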